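A few compounds are considered here, and "the series" means these few. Any claim that something is new, unique, unknown or untested is made for them only; others in the source may bear on it.

Measured compounds in a functional assay on HT-29 cells (Homo sapiens) for cytotoxicity, read by sulforhodamine B assay; a lower number here means a stronger inhibitor, a higher number a weaker inhibitor:
compound 1 `C=C1[C@@H](OC(C)=O)C[C@@H]2[C@](C)(COC=O)[C@H](OC(C)=O)CC[C@@]2(C)[C@@H]1C[C@@H](Nc1ccc(O)cc1)C1=CCOC1=O` gives 13400 nM
compound 2 `C=C1[C@@H](OC(C)=O)C[C@@H]2[C@](C)(COC=O)[C@H](OC(C)=O)CC[C@@]2(C)[C@@H]1C[C@@H](Nc1ccccc1)C1=CCOC1=O` gives 28800 nM
compound 3 `C=C1[C@@H](OC(C)=O)C[C@@H]2[C@](C)(CO[Si](C)(C)C(C)(C)C)[C@H](OC(C)=O)CC[C@@]2(C)[C@@H]1C[C@@H](Nc1ccccc1)C1=CCOC1=O` gives 4050 nM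

All three share one core and differ at two places. Compound 1 and compound 2 differ in the group on the aromatic ring attached to the nitrogen: hydroxy in place of hydrogen on an aromatic carbon. This change gives a 2.1-fold lower number from compound 2 to compound 1 (0.33 log units; beyond the scatter). Compound 2 and compound 3 differ at the oxygen on a saturated carbon: a group of 7 heavy atoms (6 carbon, 1 silicon; no ring) in place of a group of 2 heavy atoms (1 carbon, 1 oxygen; no ring), on an oxygen on a saturated carbon. This change gives a 7.1-fold lower number from compound 2 to compound 3 (0.85 log units; beyond the scatter), and compound 3 holds the lowest number of the three in this assay.

Compound 4 `C=C1[C@@H](OC(C)=O)C[C@@H]2[C@](C)(CO[Si](C)(C)C(C)(C)C)[C@H](OC(C)=O)CC[C@@]2(C)[C@@H]1C[C@@H](Nc1ccc(O)cc1)C1=CCOC1=O` has not yet been measured. It carries the same change relative to compound 3 that compound 1 carries relative to compound 2: hydroxy in place of hydrogen on an aromatic carbon. The two cores differ as described for compound 2 and compound 3, and the place of the change is the same in both pairs, so this is the same change made on a different core.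

Because the earlier step was a 2.1-fold lower number from compound 2 to compound 1 (0.33 log units; beyond the scatter), the step from compound 3 to compound 4 is expected to be of similar size, a 2.0-fold lower number from compound 3 to compound 4 (0.31 log units; beyond the scatter). Compound 4 is therefore estimated at about 2000 nM in this assay, with a likely range from 900 nM to 5000 nM.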

Compound 4, half-maximal inhibitory concentration: 6140 nM
Beside the measured number, compound 4's estimate is 3.1-fold (0.49 log units) below it, outside the stated range (above it).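

In this assay, the hydroxy on the aromatic ring does not carry over from one core to the other with the same effect: the same change on two cores in this assay, a 2.1-fold lower number (0.33 log units; beyond the scatter) from compound 2 to compound 1 and a 1.5-fold higher number (0.18 log units; within the scatter) from compound 3 to compound 4, 3.3-fold (0.51 log units) apart, beyond the scatter of two such steps

On the core with the silicon-bearing group, the change gives a 1.5-fold higher number from compound 3 to compound 4 (0.18 log units; within the scatter), so there it has no effect that can be told from the scatter, and the swap to the silicon-bearing group still lowers the number on the 4-hydroxyphenyl compounds, with a 2.2-fold lower number from compound 1 to compound 4 (0.34 log units; beyond the scatter), though by less than on the phenyl compounds: the same change on two cores in this assay, a 7.1-fold lower number (0.85 log units; beyond the scatter) from compound 2 to compound 3 and a 2.2-fold lower number (0.34 log units; beyond the scatter) from compound 1 to compound 4, 3.3-fold (0.51 log units) apart, beyond the scatter of two such steps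

So the effects of these two changes do not simply add up here, but a single pair on each core cannot show why, nor how any other ring group would behave.

The compounds shown leave open whether a methoxy group or an amine on that aromatic carbon would depend on the core in the same way. They also leave open how a smaller silyl group or a free hydroxymethyl in place of the silicon-bearing group would behave.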